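This account rests on a few compounds, and the source may have more. Where it says the series, first, only, none or still open, it means among the compounds named here.

Measured compounds:
compound 1, `C=C1C(=O)[C@]23C[C@@]1(O)CC[C@H]2c1ccc(O)c(C)c1[C@@H]3Cn1cc(-c2ccccc2)nn1`, 1160 nM
compound 2, `Cc1ccc(S(=O)(=O)Oc2ccc3c(c2C)[C@H](Cn2cc(-c4ccccn4)nn2)[C@@]24CC(=O)[C@@](C)(CC[C@@H]32)C4)cc1`, > 20000 nM
compound 3, `C=C1C[C@]23C[C@@]1(O)CC[C@H]2c1ccc(O)c(C)c1[C@@H]3Cn1cc(-c2ccc(Br)cc2)nn1`, > 20000 nM

Going by the values given here, in a functional assay on A549 cells (Homo sapiens) for cytotoxicity, read by MTT assay, with a stated time of 4 days (a higher number here means a weaker inhibitor, a lower number a stronger inhibitor), compound 1 gives 1160 nM, the only number among the three. Compound 2 reports a limit, > 20000 nM, not a number. Compound 3 likewise reports only a limit, > 20000 nM. The series therefore rests on (the limit of > 20000 nM in this assay, at which 2 of the 3 values shown sit), and compound 1 alone anchors any comparison.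

Compound 4, `C=C1C(=O)[C@]23C[C@@]1(O)CC[C@H]2c1ccc(O)c(C)c1[C@@H]3Cn1cc(-c2ccc(C(F)(F)F)cc2)nn1`, is not yet measured. It differs from compound 1 by trifluoromethyl in place of hydrogen on an aromatic carbon. Among the compounds with values here, no measured pair makes this change, so no step size can be read off. The expected step is a 2.2-fold higher number from compound 1 to compound 4 (0.33 log units; beyond the scatter), towards a weaker inhibitor in this assay, though a result within the scatter would not surprise. Compound 4 is estimated at 2500 nM, with a likely range from 800 nM to 12000 nM.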

Compound 4, half-maximal inhibitory concentration: 1110 nM
Compound 4: the middle estimate sits 2.3-fold (0.35 log units) above what was measured; the measured number falls inside the stated range.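

In this assay, a step of a 1.0-fold lower number from compound 1 to compound 4 (0.02 log units; within the scatter) shows that this position on the aromatic ring accepts trifluoromethyl in place of hydrogen with no change in the read-out beyond the scatter. Going by these compounds alone, no earlier pair could show this, since no two measured compounds differed in one place. No measurement at hand gives a reason for this result.

From the compounds shown here alone, whether an amine, a carboxylic acid or a methoxy group at this position would also leave the read-out unchanged remains open. One step at one position gives no trend across substituents.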